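Methoxy for nitro on the amide aryl ring

A few compounds are considered here, and "the series" means these few. Any claim that something is new, unique, unknown or untested is made for them only; others in the source may bear on it.

Of the compounds shown here, three sharing one core have been measured in an assay on CHO cells for agonist activity at G protein-coupled receptor GPR35 (Rattus norvegicus), read by a beta-galactosidase reporter and beta-arrestin recruitment, with a stated time of 90 min; on this read-out lower numbers stand for an effect already at smaller amounts and higher numbers for an effect only at larger amounts of compound. Compound 1 `COc1ccc(C(=O)Nc2cc(F)cc3c(=O)cc(C(=O)O)oc23)cc1` gives 1760 nM, compound 2 `Cc1cccc(C(=O)Nc2cc(Cl)cc3c(=O)cc(C(=O)O)oc23)c1` gives 2100 nM, and compound 3 `O=C(Nc1cc(Cl)cc2c(=O)cc(C(=O)O)oc12)c1ccc([N+](=O)[O-])cc1` gives 3140 nM. Compound 3 carries the highest of the three numbers, yet its gaps to compound 2 and to compound 1 both lie within the scatter, so no order among them can be claimed. Within the data shown here, the single step with one change, a 1.5-fold higher number from compound 2 to compound 3 (0.17 log units; within the scatter), was itself within the scatter.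

Compound 4 `COc1ccc(C(=O)Nc2cc(Cl)cc3c(=O)cc(C(=O)O)oc23)cc1` is the next candidate. Going from compound 3 to compound 4 the change is methoxy in place of nitro on an aromatic carbon. Among the measured compounds shown here, no measured step shows this exact exchange; the nearest evidence is compound 1, which carries the same methoxyphenyl on a fluorinated core and gives 1760 nM, close to the other two values. Since every move so far has stayed inside the scatter, compound 4 is expected to land near compound 3 with a step of a 1.6-fold lower number from compound 3 to compound 4 (0.20 log units; within the scatter) in this assay. The estimate for compound 4 is 2000 nM, with a range from 900 nM to 4500 nM.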

Compound 4, half-maximal effective concentration: 1830 nM
Beside the measured number, compound 4's estimate is 1.1-fold (0.04 log units) above it; low and high end bracket the measured number.
By their numbers in this assay, from the lowest: compounds 1, 4, 2 and 3 (each within the scatter of the next).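

In this assay, the exchange of 4-nitrophenyl for 4-methoxyphenyl can now be read directly on the chloro-bearing core: a 1.7-fold lower number from compound 3 to compound 4 (0.23 log units; within the scatter). Among these compounds, two further single changes also stay inside the scatter: a 1.1-fold lower number from compound 2 to compound 4 (0.06 log units; within the scatter), and, for the halogen on the core, a 1.0-fold higher number from compound 1 to compound 4 (0.02 log units; within the scatter), an exchange that the earlier compounds could not isolate. No evidence accompanies these values that would explain them.

Every step shown remains within the scatter, so none of these compounds shows that this aromatic carbon, the acyl aryl group or the halogen affects the read-out. As far as these compounds go, whether an amine, a carboxylic acid or a longer alkoxy chain in place of methoxy on that aromatic carbon would give a step beyond the scatter remains open.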